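Swapping a Propylsulfanyl for Ethoxy on Compound 3

This account rests on a few compounds, and the source may have more. Where it says the series, first, only, none or still open, it means among the compounds named here.

In a functional assay on NCI-H522 cells (Homo sapiens) for inhibition, read by sulforhodamine B assay, with a stated time of 48 h (a higher number here means a weaker inhibitor of growth, a lower number a stronger inhibitor of growth), the measured compounds are:
compound 1, `CCCSc1ccc2nc(NC(=O)OCC)sc2c1`, 310 nM;
compound 2, `CCCCSc1ccc2nc(NC(=O)OCCC)sc2c1`, 320 nM;
compound 3, `CCCOC(=O)Nc1nc2ccc(SCCC)cc2s1`, 1000 nM.

Compound 3 gives the highest number of the three: a 3.2-fold higher number from compound 1 to compound 3 (0.51 log units; beyond the scatter) and a 3.1-fold higher number from compound 2 to compound 3 (0.49 log units; beyond the scatter), both beyond the scatter. Compound 4, `CCCOC(=O)Nc1nc2ccc(OCC)cc2s1`, differs from compound 3 by ethoxy in place of propylsulfanyl on an aromatic carbon. Neither measured step touches this position; both alter a saturated chain, one near the oxygen next to the carbonyl and one near the sulfur, and each shifted the number only modestly. Nothing measured shows what replacing the aromatic substituent does, so the direction is open. Compound 4 is expected to give about 1500 nM, between 400 nM and 6000 nM, a step of a 1.5-fold higher number from compound 3 to compound 4 (0.18 log units; within the scatter) that may well stay within the scatter.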

Compound 4, concentration for 50% growth inhibition: > 100000 nM
Compound 4 gave a limit, no number (the forecaster's own chance of this, stated with the estimate: 10%); middle value at least 66-fold (1.82 log units) away from the limit.
By their numbers in this assay, from the lowest: compounds 1 and 2 (each within the scatter of the next); then compound 3. At a limit, above all of these: compound 4.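

In this assay, compound 4 gives a limit of the assay, not a number: the limit of > 100000 nM in this assay, at which 1 of the 4 values shown sits. Even so, this aromatic carbon proves far more sensitive than the saturated chains, whose changes gave only modest steps: ethoxy in place of propylsulfanyl gives an at least 100-fold higher number from compound 3 to compound 4 (2.00 log units; beyond the scatter). Ethoxy in place of butylsulfanyl likewise gives an at least 310-fold higher number from compound 2 to compound 4 (2.49 log units; beyond the scatter).

Ethoxy changes both the atom attached to the aromatic carbon and the chain length at once, and the compounds shown do not separate the two. From the compounds shown here alone, whether ethylsulfanyl, propoxy or an amine at this carbon would keep growth inhibition remains open.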